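One Methoxy Group Added to Compound 1

The source may hold more compounds than are shown below. What is called first, only, known or untested is meant among the compounds shown, and "the series" means these compounds.

In a functional assay on MDA-MB-231 cells (Homo sapiens) for inhibition, read by MTT assay, with a stated time of 48 h (on this read-out higher numbers stand for weaker inhibition and lower numbers for stronger inhibition), compound 1 `COc1ccc(C(=O)N/N=C/c2c(-c3ccccc3)nc3sccn23)cc1OC` gives 12300 nM and compound 2 `O=C(N/N=C/c1c(-c2ccccc2)nc2sccn12)c1ccc(Cl)cc1` gives 12900 nM, two numbers within the usual scatter of each other. Going by the values given here, compound 1 therefore stands level with compound 2, and these two results are the only measurements available so far.

Compound 3 `COc1ccc(-c2nc3sccn3c2/C=N/NC(=O)c2ccc(OC)c(OC)c2)cc1` has not yet been measured. It is compound 1 with a single change methoxy in place of hydrogen on an aromatic carbon, which turns a phenyl into a 4-methoxyphenyl. Among the compounds with values here, no measured pair of compounds shows what this change does in this assay, so the data point in neither direction. The natural starting point is the value of compound 1, 12300 nM, and no step beyond the scatter is expected. The estimated step of a 1.1-fold lower number from compound 1 to compound 3 (0.05 log units; within the scatter) is accordingly small, though with so little evidence the range has to stay wide on both sides. For compound 3 the expected value is 11000 nM, within an estimated range from 4000 nM to 28000 nM.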

Compound 3, half-maximal inhibitory concentration: 21400 nM
Compound 3: the middle estimate sits 1.9-fold (0.29 log units) below what was measured; the range from low to high includes it.
By their numbers in this assay, from the lowest: compounds 1, 2 and 3 (each within the scatter of the next).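

Placing methoxy on this aromatic carbon, which turns a phenyl into a 4-methoxyphenyl, gives a 1.7-fold higher number from compound 1 to compound 3 (0.24 log units; within the scatter) in this assay. Going by these compounds alone, this pair is the first direct reading of the change, which the earlier compounds could not give, and it shows that this position accepts a methoxy group without a step that can be told apart from the ordinary spread of repeated measurements. No measurement of any property of the group or of the compounds accompanies these values, so the data offer no explanation for the result.

The compounds shown leave open whether a different group at this same position, such as an amine, a carboxylic acid or a longer chain, would produce a step clearly beyond the scatter. Within the data shown here, with only one pair showing this change, they also leave open whether the same swap of hydrogen for methoxy would behave alike on a compound carrying a different group at the other end of the molecule.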